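This account rests on a few compounds, and the source may have more. Where it says the series, first, only, none or still open, it means among the compounds named here.

In a functional assay on MDA-MB-231 cells (Homo sapiens) for antiproliferative activity, read by MTT assay, with a stated time of 72 h (on this read-out higher numbers stand for weaker inhibition and lower numbers for stronger inhibition), compound 2 `O=C(CCc1cccc2c1B(O)OC2)Nc1cccc(-c2cccc(F)c2)c1` gives 570 nM as the lower of two numbers, against compound 1 `O=C(CCc1cccc2c1B(O)OC2)Nc1cccc(I)c1` at 5300 nM in the same read-out. The change to compound 3 `O=C(CCc1cccc2c1B(O)OC2)Nc1cccc(-c2ccc(Cl)cc2)c1` is 4-chlorophenyl in place of 3-fluorophenyl on an aromatic carbon and amounts to 4-chlorophenyl in place of 3-fluorophenyl on an aromatic carbon. Within the data shown here, only one measured step bears on it, the modest 9.3-fold lower number from compound 1 to compound 2 (0.97 log units; beyond the scatter) for 3-fluorophenyl in place of iodo, which lies beyond the scatter. Among the measured compounds shown here, no measured step exchanges one substituted phenyl for another. The expected change is therefore none beyond the scatter (a 1.1-fold higher number from compound 2 to compound 3 (0.02 log units; within the scatter)) in this assay. Compound 3 is estimated at 600 nM with an expected range from 250 nM to 1500 nM on this read-out.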

Compound 3, half-maximal inhibitory concentration: 260 nM
Compound 3: the middle estimate sits 2.3-fold (0.36 log units) above what was measured, and the stated range covers the measured number.
By their numbers in this assay, from the lowest: compound 3; then compound 2; then compound 1.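

In this assay, the aryl group at this position is not interchangeable: 4-chlorophenyl in place of 3-fluorophenyl gives a 2.2-fold lower number from compound 2 to compound 3 (0.34 log units; beyond the scatter), a step beyond the scatter. Measured against iodo, 4-chlorophenyl gives a 20-fold lower number from compound 1 to compound 3 (1.31 log units; beyond the scatter), a larger step than 3-fluorophenyl gave. Nothing available explains the difference between the two aryl groups.

These two groups differ in both halogen and its place on the ring, leaving the contribution of each unresolved; 3-chlorophenyl or 4-fluorophenyl would separate them. As far as these compounds go, how an amine or a carboxylic acid on this ring would compare also remains open.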